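The source may report more compounds than this note shows. Statements on the series, on what has been measured and on what is new or still open speak of the compounds shown alone.

Measured so far in a functional assay on IGROV-1 cells (Homo sapiens) for inhibition, read by sulforhodamine B assay, with a stated time of 48 h; a lower number here means a stronger inhibitor of growth, a higher number a weaker inhibitor of growth:
compound 1 `COc1ccc(-c2[nH]c3ccc(OC)cc3c2/C=C(\C#N)S(=O)(=O)c2ccccc2)cc1` — compound 1 gives 10600 nM
compound 2 `COc1ccc(-c2[nH]c3ccccc3c2/C=C(\C#N)S(=O)(=O)c2ccccc2)cc1` — compound 2 gives 19300 nM

Among the compounds with values here, compound 2 stands at the highest of the two numbers in this assay, with compound 1 its only neighbour; the one recorded step, a 1.8-fold higher number from compound 1 to compound 2 (0.26 log units; within the scatter), lies within the scatter, so the two compounds cannot be ordered on these data.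

Compound 3 `N#C/C(=C\c1c(-c2ccccc2)[nH]c2ccccc12)S(=O)(=O)c1ccccc1` is not yet measured in this assay. It differs from compound 2 by hydrogen in place of methoxy on an aromatic carbon. Within the data shown here, the one step that bears on it is a 1.8-fold higher number from compound 1 to compound 2 (0.26 log units; within the scatter), where the same kind of change at another aromatic carbon of the shared core gave a shift no larger than the scatter. Among the measured compounds shown here, only that single step is available, and it sits on a different ring of the core, so the bearing is indirect. From it the expected step in this assay from compound 2 to compound 3 is small, with no firm direction, possibly toward a slightly higher number.

Compound 3 is therefore estimated in this assay at 25000 nM, range 10000 nM to 65000 nM, an expected step of a 1.3-fold higher number from compound 2 to compound 3 (0.11 log units; within the scatter).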

Compound 3, concentration for 50% growth inhibition: 3300 nM
Compound 3: middle estimate off by 7.6-fold (0.88 log units), on the high side; measured number outside the range, below it.
By their numbers in this assay, from the lowest: compound 3; then compounds 1 and 2 (each within the scatter of the next).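

In this assay, within the data shown here, the change from 4-methoxyphenyl to phenyl gives a 5.8-fold lower number from compound 2 to compound 3 (0.77 log units; beyond the scatter), the first step that lies beyond the scatter. The same replacement of methoxy by hydrogen on an aromatic carbon of the shared core gave a 1.8-fold higher number from compound 1 to compound 2 (0.26 log units; within the scatter), so across these two steps the outcome of removing a methoxy differs with its place and is not set by the replacement alone. The place para to a large group on the six-membered aromatic ring of carbon only is therefore one where the choice between methoxy and hydrogen shows in growth inhibition, with hydrogen giving the lower number, though nothing available accounts for this difference.

The compounds shown leave open whether any group at that place would raise the number relative to hydrogen, or whether this is particular to methoxy; a fluorine, a methyl, a hydroxyl, an amine, a carboxylic acid or a longer alkoxy chain there would separate these readings. They also leave open whether methoxy on the shared core would stay within the scatter when the 4-methoxyphenyl is replaced by phenyl.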